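A few compounds are considered here, and "the series" means these few. Any claim that something is new, unique, unknown or untested is made for them only; others in the source may bear on it.

In a functional assay on PANC-1 cells (Homo sapiens) for inhibition, read by MTT assay, with a stated time of 24 h, tested at 10 uM (a lower number here means less inhibition, a higher number more inhibition at the concentration tested (going by the name of the read-out)), the three measured compounds give these numbers:

compound 1 `CC(C)=CCC1Cc2c(OCCCNS(=O)(=O)c3ccc(Br)cc3)cc(=O)n(CCCO)c2CC1(C)C`: 3.7%
compound 2 `CC(C)=CCC1Cc2c(OCCCNS(=O)(=O)c3ccc([N+](=O)[O-])cc3)cc(=O)n(CCCO)c2CC1(C)C`: 17.3%
compound 3 `CC(C)=CCC1Cc2c(OCCCNC(=O)c3ccc([N+](=O)[O-])cc3)cc(=O)n(CCCO)c2CC1(C)C`: 9.1%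

Compound 2 stands highest of the three. Its separation from compound 1 is a number 13.6 percentage points higher from compound 1 to compound 2 (beyond the scatter), while its separation from compound 3 is a number 8.2 percentage points lower from compound 2 to compound 3 (within the scatter). Compound 4 `CC(C)=CCC/C(C)=C/CC1Cc2c(OCCCNS(=O)(=O)c3ccc([N+](=O)[O-])cc3)cc(=O)n(CCCO)c2CC1(C)C` is built from compound 2 by one change: 3-methylbut-2-en-1-yl in place of hydrogen on a saturated chain carbon bound to a double-bonded chain carbon. For the measured compounds named here, none of the measured steps touches this part of the molecule; they exchange the group on the amine nitrogen or the group on the aromatic carbon. So no measured step bears on the change, and no step beyond the scatter is expected in this assay. Compound 4 is therefore estimated at 17%, between 4% and 32%, an expected step of a number 0.3 percentage points lower from compound 2 to compound 4 (within the scatter).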

Compound 4, a percentage reported as inhibition, at one concentration (the size of the read-out at that concentration, not a potency): 0%
Compound 4: the middle estimate sits 17 percentage points above what was measured; measured number outside the range, below it.
By their numbers in this assay, from the lowest: compounds 4, 1, 3 and 2 (each within the scatter of the next, the first and the last beyond it).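

Lengthening 3-methylbut-2-en-1-yl to 3,7-dimethylocta-2,6-dien-1-yl gives in this assay a step of a number 17.3 percentage points lower from compound 2 to compound 4 (beyond the scatter) and so shows that this side chain, untouched by the earlier steps, can change the read-out. The inhibition seen with the nitro sulfonamide compound 2 does not survive this longer chain. No available evidence explains the drop.

Still open, going by these compounds, is whether a shorter chain, such as methyl, would keep the inhibition, and whether an amine or a carboxylic acid at the end of the longer chain would restore it.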